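Dienone series on HeLa: pyridin-3-yl for 4-fluorophenyl

The source may hold more compounds than are shown below. What is called first, only, known or untested is meant among the compounds shown, and "the series" means these compounds.

Measured in a functional assay on HeLa cells (Homo sapiens) for cytotoxicity, read by sulforhodamine B assay, with a stated time of 48 h; on this read-out higher numbers stand for weaker inhibition and lower numbers for stronger inhibition:
compound 1 `CC1=C(/C=C/C(=O)/C=C/c2ccc(F)cc2)C(C)(C)CCC1` — 32200 nM
compound 2 `CC1=C(/C=C/C(=O)/C=C/c2ccc([N+](=O)[O-])cc2)C(C)(C)CCC1` — 28700 nM
compound 3 `CC1=C(/C=C/C(=O)/C=C/c2ccc(Cl)c(Cl)c2)C(C)(C)CCC1` — > 100000 nM, a limit of the assay, not a number

Compound 1 and compound 2 lie within the scatter of each other: a 1.1-fold lower number from compound 1 to compound 2 (0.05 log units; within the scatter). Compound 3 stands at the limit (the limit of > 100000 nM in this assay, at which 1 of the 3 values shown sits). So among the numbered values no step beyond the scatter has been seen, and the only measured step on the aryl ring, nitro for fluoro, moved nothing.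

Compound 4 `CC1=C(/C=C/C(=O)/C=C/c2cccnc2)C(C)(C)CCC1` differs from compound 1 by pyridin-3-yl in place of 4-fluorophenyl on a double-bonded chain carbon bound to a double-bonded chain carbon. Going by the values given here, no measured step touches a ring exchange of this kind; the nitro-for-fluoro step is the nearest precedent and it stayed within the scatter. A step beyond the scatter in this assay is therefore not expected in either direction, with the limit of compound 3 as a reminder that the read-out can also run out of range. Compound 4 is estimated at 35000 nM, between 12000 nM and 100000 nM, which means an expected step of a 1.1-fold higher number from compound 1 to compound 4 (0.04 log units; within the scatter).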

Compound 4, half-maximal inhibitory concentration: 17400 nM
Compound 4: middle estimate off by 2.0-fold (0.30 log units), on the high side; low and high end bracket the measured number.
By their numbers in this assay, from the lowest: compounds 4, 2 and 1 (each within the scatter of the next). At a limit, above all of these: compound 3.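

In this assay, pyridin-3-yl in place of 4-fluorophenyl gives a 1.9-fold lower number from compound 1 to compound 4 (0.27 log units; within the scatter); this exchanges the whole aromatic ring rather than one group on it, and it brings in a hetero atom and a hydrogen-bond acceptor without a step beyond the scatter. Nothing shown accounts for the size of this step, or says what the ring nitrogen contributes. Compound 3 stands at > 100000 nM, which is a limit of the assay and not a number, so it remains the exception to this flat picture among the compounds shown.

Open, as far as these compounds go, is whether pyridin-4-yl, or an amine or a carboxylic acid on the aromatic ring, would give a step beyond the scatter. Also open, from the compounds shown here alone, is whether any exchange at this place gives a number well below those of compounds 1, 2 and 4.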